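Three Anilino-Pyrazolone Imines and a Fourth to Come

The source may report more compounds than this note shows. Statements on the series, on what has been measured and on what is new or still open speak of the compounds shown alone.

Three compounds share one core and differ only in the aromatic ring hanging from the carbon that is double-bonded to nitrogen. Compound 1 `CCOc1cccc(/C=N/c2c(C)n(C)n(-c3ccccc3)c2=O)c1` gives 295000000 nM in a functional assay on HT-29 cells (Homo sapiens) for cytotoxicity, read by MTT assay, with a stated time of 72 h; a lower number here means a stronger inhibitor, a higher number a weaker inhibitor. Compound 2 `Cc1c(/N=C/c2cccc(O)c2)c(=O)n(-c2ccccc2)n1C` gives 166000000 nM in the same assay, and the change a 1.8-fold lower number from compound 1 to compound 2 (0.25 log units; within the scatter). Compound 3 `Cc1c(/N=C/c2ccc(Cl)cc2Cl)c(=O)n(-c2ccccc2)n1C` gives 178000000 nM; it stands second highest of the three numbers, with compound 2 nearest and compound 1 furthest, and both gaps sit within the scatter. The step of a 1.1-fold higher number from compound 2 to compound 3 (0.03 log units; within the scatter) is likewise within the scatter.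

Compound 4 `Cc1c(/N=C/c2cccc(Cl)c2)c(=O)n(-c2ccccc2)n1C` differs from compound 3 by 3-chlorophenyl in place of 2,4-dichlorophenyl on a carbon with a double bond to nitrogen. The step from compound 2 to compound 3, which also swapped the aromatic ring on this carbon, is the one that bears on this change, and it was within the scatter; the step from compound 1 to compound 2 was also within the scatter. A change no larger than the scatter is therefore expected, with compound 4 estimated at 190000000 nM, between 80000000 nM and 450000000 nM, a step of a 1.1-fold higher number from compound 3 to compound 4 (0.03 log units; within the scatter).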

Compound 4, half-maximal inhibitory concentration: 269000000 nM
Compound 4: middle estimate off by 1.4-fold (0.15 log units), on the low side; the measured number falls inside the stated range.
By their numbers in this assay, from the lowest: compounds 2, 3, 4 and 1 (each within the scatter of the next).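

On the carbon with a double bond to nitrogen, 3-chlorophenyl in place of 2,4-dichlorophenyl gives a 1.5-fold higher number from compound 3 to compound 4 (0.18 log units; within the scatter), so this further ring change also stays within the scatter. Chloro in place of hydroxy gives a 1.6-fold higher number from compound 2 to compound 4 (0.21 log units; within the scatter), and chloro in place of ethoxy gives a 1.1-fold lower number from compound 1 to compound 4 (0.04 log units; within the scatter), so across these four compounds chloro, hydroxy and ethoxy on the aromatic ring cannot be told apart by their numbers. Nothing available explains why these steps are so small.

As far as these compounds go, whether an amine or a carboxylic acid on this aromatic ring would move the number beyond the scatter remains open. The compounds shown also leave open what a change elsewhere on the shared core would do, such as a longer chain in place of a methyl group.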